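Chain Length and Core Change in Amine Oxidase B Inhibitors

The source may report more compounds than this note shows. Statements on the series, on what has been measured and on what is new or still open speak of the compounds shown alone.

Three compounds have been measured in an assay on BTI cells for inhibition of Amine oxidase [flavin-containing] B (Homo sapiens), read by fluorescence and Amplex Red, with a stated time of 15 min; a lower number here means a stronger inhibitor, a higher number a weaker inhibitor:
compound 1, `C#CCN(C)CCCCOc1ccc2c(c1)CCC2=O`, 366 nM;
compound 2, `C#CCN(C)CCCCCOc1ccc2c(c1)CCC2=O`, 94.8 nM;
compound 3, `C#CCN(C)CCCCCOc1ccc2c(c1)OCCC2=O`, 4 nM.

From compound 1 to compound 2 the change is (methyl(propargyl)amino)methyl in place of methyl(propargyl)amino on a saturated chain carbon, four bonds along the chain from an oxygen on an aromatic ring, and the step is a 3.9-fold lower number from compound 1 to compound 2 (0.59 log units; beyond the scatter). Compound 3 has a different core from compound 1; that difference is not broken down here. Compound 3 gives the lowest number of the three.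

Compound 4, `C#CCN(C)CCCCCCOc1ccc2c(c1)OCCC2=O`, awaits measurement in this assay. It differs from compound 3 by (methyl(propargyl)amino)methyl in place of methyl(propargyl)amino on a saturated chain carbon, five bonds along the chain from an oxygen on an aromatic ring, the same kind of change as from compound 1 to compound 2, though placed five bonds along the chain from an oxygen on an aromatic ring rather than four. Because the measured step of a 3.9-fold lower number from compound 1 to compound 2 (0.59 log units; beyond the scatter) was modest, a step of similar direction is expected, a 1.6-fold lower number from compound 3 to compound 4 (0.20 log units; within the scatter), resting on that single example. Compound 4 is estimated at 2.5 nM, between 0.8 nM and 10 nM.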

Compound 4, half-maximal inhibitory concentration: 117 nM
For compound 4 the middle estimate is 47-fold (1.67 log units) below the measured one, outside the stated range (above it).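

In this assay the change does not carry over from one core to the other, since a 29-fold higher number from compound 3 to compound 4 (1.47 log units; beyond the scatter) runs against the step seen on the other core, and the two steps clearly differ: the same change on two cores in this assay, a 3.9-fold lower number (0.59 log units; beyond the scatter) from compound 1 to compound 2 and a 29-fold higher number (1.47 log units; beyond the scatter) from compound 3 to compound 4, 110-fold (2.05 log units) apart, beyond the scatter of two such steps
In this series, then, neither the size nor the direction of this change can be assumed to hold across the two cores. For the compounds shown here, the comparison does not show that the core alone decides the outcome, since the two steps also sit at different places along the chain and form only one pair.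

On these data alone, it remains open how the chain of compound 4 behaves on the core of compound 1. As far as these compounds go, a longer chain, with 2-(methyl(propargyl)amino)ethyl on either core, also remains open.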